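This account rests on a few compounds, and the source may have more. Where it says the series, first, only, none or still open, it means among the compounds named here.

Within the data shown here, compound 3 `N#Cc1ccc(Cc2cnc(CCc3ccc(-c4ccccc4C(=O)O)cc3)[nH]2)cc1` gives 723 nM in an in vitro functional assay on cells for agonist activity at Bombesin receptor subtype-3 (Mus musculus), read by luminescence and calcium flux (on this read-out higher numbers stand for an effect only at larger amounts of compound and lower numbers for an effect already at smaller amounts), the highest of the three numbers measured so far: compound 1 `O=C(O)c1ccccc1-c1ccc(CCc2ncc(Cc3cccc(Cl)c3)[nH]2)cc1` gives 31 nM and compound 2 `N#Cc1cccc(Cc2cnc(CCc3ccc(-c4ccccc4C(=O)O)cc3)[nH]2)c1` gives 20 nM. Compound 4 `COc1ccc(Cc2cnc(CCc3ccc(-c4ccccc4C(=O)O)cc3)[nH]2)cc1` differs from compound 3 by methoxy in place of cyano on an aromatic carbon. Among the measured compounds shown here, no measured step exchanges a cyano for a methoxy, so the change itself has no direct precedent. The steps that touch the same part of the molecule are a 23-fold higher number from compound 1 to compound 3 (1.37 log units; beyond the scatter) and a 36-fold higher number from compound 2 to compound 3 (1.56 log units; beyond the scatter), whereas a 1.6-fold lower number from compound 1 to compound 2 (0.19 log units; within the scatter). Compound 4 carries a 4-methoxybenzyl where compound 3 carries a 4-cyanobenzyl, and on that basis a 1.2-fold lower number from compound 3 to compound 4 (0.08 log units; within the scatter) is expected, without a firm direction. Compound 4 is therefore estimated at 600 nM, with a range from 150 nM to 2500 nM.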

Compound 4, half-maximal effective concentration: 513 nM
For compound 4 the middle estimate is 1.2-fold (0.07 log units) above the measured one; the range from low to high includes it.
By their numbers in this assay, from the lowest: compounds 2 and 1 (each within the scatter of the next); then compounds 4 and 3 (each within the scatter of the next).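

In this assay methoxy in place of cyano, para to a large group, gives a 1.4-fold lower number from compound 3 to compound 4 (0.15 log units; within the scatter) and so does not separate these two groups at this place. Compound 4 stays far from the other two compounds, with a 26-fold higher number from compound 2 to compound 4 (1.41 log units; beyond the scatter) and a 17-fold higher number from compound 1 to compound 4 (1.22 log units; beyond the scatter) as large steps, so the large gap seen with 4-cyanophenyl is not confined to the nitrile. Going by these compounds, whether an amine or a hydroxyl in the place of the methoxy gives a similar number remains open, as does how a methoxy on the ring carbon holding the chloro of compound 1 would compare. No measured evidence accounts for this result.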